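Chloro for fluoro on a fused core: microsomal half-life

The source may report more compounds than this note shows. Statements on the series, on what has been measured and on what is new or still open speak of the compounds shown alone.

Measured compounds:
compound 1, `Fc1ccc2c(-c3ccc4ccccc4n3)c[nH]c2c1Cl`, 0.183 h
compound 2, `Fc1ccc2c(-c3ccc4ccccc4n3)c[nH]c2c1F`, 0.167 h
compound 3, `Fc1cc(Cl)cc2c(-c3ccc4ccccc4n3)c[nH]c12`, 0.633 h

In an ADME assay on microsomes from liver (Homo sapiens) for metabolic stability, using NADPH, with a stated time of 40 min, tested at 2 uM (on this read-out higher numbers stand for a longer-lived compound and lower numbers for a shorter-lived compound), compound 2 and compound 1 are linked by one change, (chloro in place of fluoro on an aromatic carbon), which gave a 1.1-fold higher number from compound 2 to compound 1 (0.04 log units; within the scatter). Compound 3 gives the highest of the three numbers; the difference between the core of compound 3 and the core of compound 2 is not broken down here. Compound 4, `Clc1cc(Cl)c2[nH]cc(-c3ccc4ccccc4n3)c2c1`, has not yet been measured. It differs from compound 3 by chloro in place of fluoro on an aromatic carbon. This is the same kind of change as that from compound 2 to compound 1, though the place differs: there the carbon was ortho to a fluoro group, here it is meta to a chloro group. Because a 1.1-fold higher number from compound 2 to compound 1 (0.04 log units; within the scatter) stayed within the scatter, compound 4 is expected to give 0.65 h, a step of a 1.0-fold higher number from compound 3 to compound 4 (0.01 log units; within the scatter), with a likely range of 0.35 h to 1.2 h.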

Compound 4, half-life: 2.57 h
Compound 4: middle estimate off by 4.0-fold (0.60 log units), on the low side; the measured number lies above the stated range.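

In this assay, chloro in place of fluoro did not carry over from one core to the other with the same size, giving a 4.1-fold higher number from compound 3 to compound 4 (0.61 log units; beyond the scatter), and the two steps differ: the same change on two cores in this assay, a 1.1-fold higher number (0.04 log units; within the scatter) from compound 2 to compound 1 and a 4.1-fold higher number (0.61 log units; beyond the scatter) from compound 3 to compound 4, 3.7-fold (0.57 log units) apart, beyond the scatter of two such steps The size of this change therefore cannot be taken from one core to the other in this series. Within the data shown here, with only two pairs, which differ in both the core and the place of the change, the data do not show which of these sets the gap, nor do they give any general rule.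

From the compounds shown here alone, it remains open how an amine or a methoxy group would compare with chloro and fluoro on that aromatic carbon. Going by these compounds, the size of the step on any further core also remains open.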